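A few compounds are considered here, and "the series" means these few. Any claim that something is new, unique, unknown or untested is made for them only; others in the source may bear on it.

Measured so far:
compound 1 `CCCC[C@@H](/C=C\[C@@H]1OC(=O)C=C[C@@H]1OC(C)=O)OC(C)=O` — 3200 nM
compound 2 `CCCC[C@H](/C=C\[C@@H]1OC(=O)C=C[C@@H]1O)OC(C)=O` — 1300 nM

In a functional assay on MCF7 cells (Homo sapiens) for cytotoxicity, read by sulforhodamine B assay, with a stated time of 48 h (on this read-out lower numbers stand for stronger inhibition and higher numbers for weaker inhibition), compound 2 gives the lowest of the two numbers; the nearest is compound 1, whose value lies beyond the scatter above it. Compound 3 `CCCC[C@H](/C=C\[C@@H]1OC(=O)C=C[C@@H]1OC(C)=O)OC(C)=O` differs from compound 2 by acetyl in place of hydrogen on an oxygen on a saturated carbon. For the measured compounds named here, no step between measured compounds covers this change, and compound 1 carries a differently configured side chain, so its value is only a loose hint. A modest weakening is expected, a 1.5-fold higher number from compound 2 to compound 3 (0.19 log units; within the scatter), with compound 3 estimated at 2000 nM and a range of 700 nM to 6000 nM.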

Compound 3, half-maximal inhibitory concentration: 500 nM
For compound 3 the middle estimate is 4.0-fold (0.60 log units) above the measured one; measured number below the stated range.
By their numbers in this assay, from the lowest: compound 3; then compound 2; then compound 1.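

In this assay, hydroxy to acetoxy on this oxygen gives a 2.6-fold lower number from compound 2 to compound 3 (0.41 log units; beyond the scatter), so a free hydroxy is not required here for the lower number. The configuration at the saturated chain carbon also counts, with a 6.4-fold lower number from compound 1 to compound 3 (0.81 log units; beyond the scatter). That step can be assigned to configuration alone, because nothing else separates the pair: the fact that compounds 1 and 3 differ only in the configuration as drawn

Open, as far as these compounds go, is whether the acetyl step holds with the side-chain configuration of compound 1. Also open, from the compounds shown here alone, is whether a benzoate ester or an amine in place of the acetoxy group keeps the lower number.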